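The source may report more compounds than this note shows. Statements on the series, on what has been measured and on what is new or still open speak of the compounds shown alone.

The compounds described here share a triazole-bearing chain attached to a carbon that also carries a chlorinated aromatic ring, and they were examined for how strongly they harm a human cell line. In an ADME assay on RD cells (Homo sapiens) for cytotoxicity, read by MTT assay, with a stated time of 3 days (on this read-out lower numbers stand for higher toxicity in this test and higher numbers for lower toxicity in this test), compound 1, with the structure `CCCC[C@@H](CCn1cncn1)c1ccc(Cl)cc1`, gives 18.7 ug/mL. Compound 2, whose structure is `CCCC[C@@H](CCn1cncn1)c1ccc(Cl)cc1Cl`, differs from compound 1 by chloro in place of hydrogen on an aromatic carbon, and in this assay compound 2 gives 1.9 ug/mL. That single change produced a 9.8-fold lower number from compound 1 to compound 2 (0.99 log units; beyond the scatter), so adding the chloro group made the compound considerably more harmful to the cells.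

Compound 3, with the structure `Clc1ccc([C@@H](CCn2cncn2)Cc2ccccc2)cc1`, carries a different core; the difference between the core of compound 3 and that of compound 1 is not broken down here. In this assay compound 3 gives 24.4 ug/mL, a number close to that of compound 1 and well apart from that of compound 2.

Compound 4, whose structure is `Clc1ccc([C@@H](CCn2cncn2)Cc2ccccc2)c(Cl)c1`, has not yet been measured. It differs from compound 3 by chloro in place of hydrogen on an aromatic carbon, the same change that turned compound 1 into compound 2. Because that earlier change gave a 9.8-fold lower number from compound 1 to compound 2 (0.99 log units; beyond the scatter), a step of similar size is expected on the new core, namely an 8.1-fold lower number from compound 3 to compound 4 (0.91 log units; beyond the scatter). On that basis compound 4 is expected to give 3 ug/mL, with the estimate running from 1.2 ug/mL to 8 ug/mL.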

Compound 4, half-maximal cytotoxic concentration: 6.5 ug/mL
The estimate for compound 4 lay 2.2-fold (0.34 log units) below the measured number; measured number inside the range.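

On the new core, chloro in place of hydrogen on an aromatic carbon again moves the result towards higher toxicity in this assay, with a 3.8-fold lower number from compound 3 to compound 4 (0.57 log units; beyond the scatter), which is the same direction as on the first core. Set side by side, the two steps are no further apart than two such steps can be by chance alone: the same change on two cores in this assay, a 9.8-fold lower number (0.99 log units; beyond the scatter) from compound 1 to compound 2 and a 3.8-fold lower number (0.57 log units; beyond the scatter) from compound 3 to compound 4, 2.6-fold (0.42 log units) apart, within the scatter of two such steps So on these two cores the change carries over in direction and, within the scatter, in size, but two pairs of compounds cannot show that it would do so on other cores, and these numbers do not explain why the added chloro group makes the compounds more harmful to the cells.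

The compounds shown leave open whether a different group on that aromatic carbon, such as a fluoro group, a methoxy group or an amine, would lower the number as chloro does. They also leave open whether the step would persist with a longer chain on the carbon that carries the aromatic ring, or in a human cell line other than RD cells.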